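The source may report more compounds than this note shows. Statements on the series, on what has been measured and on what is new or still open speak of the compounds shown alone.

Working notes on the urea series. Three analogues share one core and differ only in the group on the amide-type nitrogen. Compound 1 `Cc1ccc(NC(=O)Nc2cccc(CNc3nccnc3Cl)c2)cc1` gives 11900 nM in a functional assay on MGC-803 cells (Homo sapiens) for antiproliferative activity, read by MTT assay, with a stated time of 48 h; a lower number here means a stronger inhibitor, a higher number a weaker inhibitor. Compound 2 `CCOc1ccc(NC(=O)Nc2cccc(CNc3nccnc3Cl)c2)cc1` gives 7240 nM, and compound 3 `Cc1ccc(NC(=O)Nc2cccc(CNc3nccnc3Cl)c2)cc1Cl` gives 17500 nM. Compound 3 thus sits at the top of the three numbers, but only loosely so: the step of a 1.5-fold higher number from compound 1 to compound 3 (0.17 log units; within the scatter) stays within the scatter, while the step of a 2.4-fold higher number from compound 2 to compound 3 (0.38 log units; beyond the scatter) is a modest shift beyond it. The step of a 1.6-fold lower number from compound 1 to compound 2 (0.22 log units; within the scatter) is also within the scatter, so the whole set spans little.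

Compound 4 `O=C(Nc1cccc(CNc2nccnc2Cl)c1)NC1CCCCC1` has not yet been measured. Against compound 3 the change is cyclohexyl in place of 3-chloro-4-methylphenyl on an amide-type nitrogen. For the measured compounds named here, all three measured steps vary the group on this same amide-type nitrogen, which makes them the only relevant guide, yet each of them keeps an aromatic ring in place and only changes what sits on it; none exchanges the ring itself for a saturated one, so the present change is untested. Given that the measured steps moved the number by at most a modest amount, the expectation for compound 4 in this assay is a number near that of compound 3, with no step beyond the scatter in either direction, but with wide uncertainty. Compound 4 is therefore estimated at 14000 nM, with a range of 4000 nM to 50000 nM. This corresponds to an expected step of a 1.3-fold lower number from compound 3 to compound 4 (0.10 log units; within the scatter).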

Compound 4, half-maximal inhibitory concentration: > 40000 nM
Compound 4 gave a limit, no number (the forecaster's own chance of this, stated with the estimate: 15%); middle value at least 2.8-fold (0.45 log units) away from the limit.
By their numbers in this assay, from the lowest: compounds 2, 1 and 3 (each within the scatter of the next, the first and the last beyond it). At a limit, above all of these: compound 4.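

In this assay, compound 4 gives a limit and not a number: the limit of > 40000 nM in this assay, at which 1 of the 4 values shown sits. The three aromatic groups on the amide-type nitrogen stay close together, spanning no more than a 2.4-fold higher number from compound 2 to compound 3 (0.38 log units; beyond the scatter), whereas cyclohexyl stands apart from each of them: an at least 2.2-fold higher number from compound 3 to compound 4 (0.35 log units; beyond the scatter), an at least 5.5-fold higher number from compound 2 to compound 4 (0.74 log units; beyond the scatter) and an at least 3.3-fold higher number from compound 1 to compound 4 (0.52 log units; beyond the scatter). This position therefore does not treat the six-membered rings alike: among the four compounds shown, the three values that can be read as numbers all carry an aromatic ring of carbon here, and the one non-aromatic ring ends at the limit.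

The size of the change from the aromatic ring to cyclohexyl stays undefined, as all three steps are open-ended, and a single saturated ring cannot show whether the shift belongs to cyclohexyl alone or to non-aromatic groups in general. Also open, as far as these compounds go, is how an unsubstituted phenyl, a cyclopentyl, a benzyl or a piperidine ring on this nitrogen would read in this assay.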